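The compounds below may be only part of what the source reports. "The series", "measured", "known", "first", "only" and "open" are said of these compounds alone.

Measured in an ADME assay on microsomes from liver (Mus musculus) for metabolic stability, read by LC-MS, using NADPH, with stated times of 10 min and 30 min; a higher number here means faster removal of the compound, a lower number slower removal:
- Compound 1 `CC(=O)N[C@@H]1CCCc2c1cncc2N1C(=O)c2ccc(Cl)cc2[C@@H]1C`: < 20.2 mL/min/kg (a limit)
- Compound 2 `CC(=O)N[C@@H]1CCCc2c1cncc2N1C(=O)c2ccc(Cl)cc2[C@H]1C`: 43.5 mL/min/kg
- Compound 3 `CC(=O)N[C@@H]1CCCc2c1cncc2N1Cc2cc(Cl)ccc2C1=O`: < 20.2 mL/min/kg (a limit)

For the measured compounds named here, compound 2 carries the only true number in this set. The other two results are bounded by the limit of < 20.2 mL/min/kg in this assay, at which 2 of the 3 values shown sit.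

Compound 4 `CCC(=O)N[C@@H]1CCCc2c1cncc2N1C(=O)c2ccc(Cl)cc2[C@H]1C` differs from compound 2 as follows: methyl in place of hydrogen on a saturated chain carbon bound to a carbonyl carbon. Acetamido thus becomes propanoylamino.

Two measured steps show that the number in this assay can move: an at least 2.1-fold higher number from compound 1 to compound 2 (0.33 log units; beyond the scatter) and an at least 2.1-fold lower number from compound 2 to compound 3 (0.33 log units; beyond the scatter). Each was at least modest, but both lie at a saturated ring carbon, so neither tests a change to the acetamido group. No step beyond the scatter is therefore expected from compound 2 to compound 4. Compound 2 itself stands at 43.5 mL/min/kg. The expected change is a 1.1-fold higher number from compound 2 to compound 4 (0.06 log units; within the scatter). For compound 4, the estimated clearance is 50 mL/min/kg, with an expected range of 27 mL/min/kg to 90 mL/min/kg.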

Compound 4, clearance: 45.6 mL/min/kg
Beside the measured number, compound 4's estimate is 1.1-fold (0.04 log units) above it; the measured number falls inside the stated range.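

In this assay, for the compounds shown here, this is the first look at the acetamido group itself, and the change to propanoylamino gives a 1.0-fold higher number from compound 2 to compound 4 (0.02 log units; within the scatter). One added methyl on this saturated chain carbon bound to a carbonyl carbon therefore stays within the scatter, whereas the earlier readable steps, at a saturated ring carbon, went beyond it. Nothing shown gives a cause for this result.

The compounds shown leave open how a longer chain such as butanoyl, or an amine on this chain, would read. One added methyl cannot show how far this position stays so quiet.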